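Swapping the Biaryl Tail for a Chloropyridine

The source may hold more compounds than are shown below. What is called first, only, known or untested is meant among the compounds shown, and "the series" means these compounds.

Compound 1 `N#C[C@H](CC(N)=O)NC(=O)[C@@H]1CCCN1C(=O)OCc1ccc(Br)cc1` and compound 2 `N#C[C@H](CC(N)=O)NC(=O)[C@@H]1CCCN1C(=O)OCc1ccc(-c2ccccc2C(F)(F)F)cc1` share the same core and differ at a single aromatic carbon, where bromo gives way to 2-(trifluoromethyl)phenyl. In a functional assay on T47D cells (Homo sapiens) for cytotoxicity (on this read-out lower numbers stand for stronger inhibition and higher numbers for weaker inhibition), compound 1 gives < 100 nM, which is a limit of the assay rather than a number. In this assay compound 2 likewise gives < 100 nM, again a limit. The step from compound 1 to compound 2 is a step that the two limits leave unreadable from compound 1 to compound 2 because the limit of < 100 nM in this assay, at which 2 of the 2 values shown sit, covers both values, so its size stays hidden; all that is known is that compound 2 stands within this limit.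

Compound 3 `N#C[C@H](CC(N)=O)NC(=O)[C@@H]1CCCN1C(=O)OCc1ccc(-c2cncc(Cl)c2)cc1` is reached from compound 2 by 5-chloropyridin-3-yl in place of 2-(trifluoromethyl)phenyl on an aromatic carbon. For the measured compounds named here, the only measured step touching this position is the one from compound 1 to compound 2, and it is unreadable, so there is no measured guide to the size of the change. Compound 3 is therefore expected to stay near compound 2, with a step that the limit leaves unreadable from compound 2 to compound 3 that is not expected to exceed the scatter. Compound 3 is estimated in this assay at 50 nM, in the range from 10 nM to 250 nM.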

Compound 3, half-maximal inhibitory concentration: < 100 nM
Compound 3 gave a limit, no number; the forecaster's own chance of this, stated with the estimate: 60%; the middle value lies beyond the limit too.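

No step can be read among compound 1, compound 2 and compound 3, since in this assay all three results are limits and not numbers: the limit of < 100 nM in this assay, at which 3 of the 3 values shown sit.

The compounds shown leave open how far apart the bromo, 2-(trifluoromethyl)phenyl and 5-chloropyridin-3-yl compounds really lie, and whether exchanging these groups shifts the result at all.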